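The compounds below may be only part of what the source reports. "The series", "measured", "known", "first", "only" and "open" are said of these compounds alone.

Measured so far in a functional assay on MCF7 cells (Homo sapiens) for antiproliferative activity, read by MTT assay, with a stated time of 24 h; a lower number here means a stronger inhibitor, a higher number a weaker inhibitor:
- compound 1 `COC(=O)c1scc(-c2ccc(NC(=O)c3ccccn3)cc2)c1OC`: 19200 nM
- compound 2 `COC(=O)c1scc(-c2ccc(NC(=O)c3cccc(I)c3)cc2)c1OC`: 12300 nM
- compound 3 `COC(=O)c1scc(-c2ccc(NC(=O)c3cccc(OC(F)(F)F)c3)cc2)c1OC`: 2220 nM

Compound 2, at 12300 nM, stays at the high end of these numbers. Its nearest neighbour comes with a 1.6-fold lower number from compound 1 to compound 2 (0.19 log units; within the scatter), and its furthest with a 5.5-fold lower number from compound 2 to compound 3 (0.74 log units; beyond the scatter).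

The next compound, compound 4 `COC(=O)c1scc(-c2ccc(NC(=O)c3ccc(C(F)(F)F)cc3)cc2)c1OC`, differs from compound 2 in one place: 4-(trifluoromethyl)phenyl in place of 3-iodophenyl on a carbonyl carbon. It carries 4-(trifluoromethyl)phenyl in place of 3-iodophenyl on a carbonyl carbon.

Among the compounds with values here, two measured steps bear on this change. The closer one is a 5.5-fold lower number from compound 2 to compound 3 (0.74 log units; beyond the scatter), where trifluoromethoxy replaced iodo on an aromatic carbon. Within the data shown here, compound 4 loses the iodo as well, but it carries a different group, and no measured compound has that group. The other is a 1.6-fold lower number from compound 1 to compound 2 (0.19 log units; within the scatter), an exchange at the same carbonyl carbon that stayed within the scatter. Among the measured compounds shown here, with only these two steps to go on, a modest fall in this assay is expected, smaller than the one seen for compound 3. The expected change is a 2.5-fold lower number from compound 2 to compound 4 (0.39 log units; beyond the scatter). For compound 4 the estimated value is 5000 nM, with an expected range from 1800 nM to 13000 nM.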

Compound 4, half-maximal inhibitory concentration: 24600 nM
For compound 4 the middle estimate is 4.9-fold (0.69 log units) below the measured one, outside the stated range (above it).
By their numbers in this assay, from the lowest: compound 3; then compounds 2, 1 and 4 (each within the scatter of the next).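

The change does not carry over the fall seen for compound 3: in this assay, the exchange gives a 2.0-fold higher number from compound 2 to compound 4 (0.30 log units; within the scatter), and the comparison with the pyridine amide gives a 1.3-fold higher number from compound 1 to compound 4 (0.11 log units; within the scatter). At this carbonyl carbon, then, 3-iodophenyl, pyridin-2-yl and 4-(trifluoromethyl)phenyl cannot be told apart in this assay, so the loss of the iodo alone does not bring the number down to that of compound 3 at 2220 nM. Nothing available here accounts for this result.

The compounds shown leave open whether the low number of compound 3 belongs to the trifluoromethoxy group itself or to where it sits on the ring, as compound 3 and compound 4 differ in both the group and its place. They also leave open how a phenyl ring bearing an amine or a carboxylic acid would read in this assay at this same carbonyl carbon.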